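Cutting the Long Selenium Chain Back

The source may report more compounds than this note shows. Statements on the series, on what has been measured and on what is new or still open speak of the compounds shown alone.

Among the compounds with values here, in a functional assay on HepG2 cells (Homo sapiens) for inhibition, read by MTT assay, with a stated time of 48 h (a lower number here means a stronger inhibitor, a higher number a weaker inhibitor), compound 1 `COc1ccc(N(C)c2nc(C)nc3ccccc23)cc1[Se]C` gives 17 nM, while compound 2 `COc1ccc(N(C)c2nc(C)nc3ccccc23)cc1C(=O)OCCCC[Se]C#N` gives 975 nM, the higher of the two numbers so far. Compound 3 `COc1ccc(N(C)c2nc(C)nc3ccccc23)cc1[Se]C#N` has not yet been measured. Its structure departs from that of compound 2 in one place: a group of 3 heavy atoms (1 carbon, 1 nitrogen, 1 selenium; no ring) in place of a group of 10 heavy atoms (6 carbon, 1 nitrogen, 2 oxygen, 1 selenium; no ring), on an aromatic carbon. The change sits on an aromatic carbon, ortho to a methoxy group. Within the data shown here, only one measured step bears on it, a 57-fold higher number from compound 1 to compound 2 (1.76 log units; beyond the scatter), which is large and beyond the scatter and came with a long chain taking the place of a small selenium group. Compound 3 again carries a small selenium group, but a different one from compound 1, so only most of that step is likely to be reversed. A large drop in the number is therefore expected in this assay, an estimated 24-fold lower number from compound 2 to compound 3 (1.39 log units; beyond the scatter). Compound 3 is expected at about 40 nM, within an estimated range of 10 nM to 200 nM.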

Compound 3, half-maximal inhibitory concentration: 59 nM
Beside the measured number, compound 3's estimate is 1.5-fold (0.17 log units) below it, and the stated range covers the measured number.
By their numbers in this assay, from the lowest: compound 1; then compound 3; then compound 2.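

In this assay, the small group on this aromatic carbon restores most of the number: the step is a 17-fold lower number from compound 2 to compound 3 (1.22 log units; beyond the scatter) and it is large, though both compounds carry cyano on selenium. That group therefore works with selenium bound directly to the aromatic carbon, and the longer attachment of 10 heavy atoms accompanies the higher number. Cyano in place of methyl on selenium, seen in a 3.5-fold higher number from compound 1 to compound 3 (0.54 log units; beyond the scatter) and beyond the scatter, is a modest step, so the two small selenium groups stay fairly close, and nothing at hand accounts for either step.

The compounds shown leave open how a shorter chain carrying cyano on selenium would read at this position. They also leave open whether selenium is needed at all, as an amine or a methylthio group on this carbon would show.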